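The source may hold more compounds than are shown below. What is called first, only, known or untested is meant among the compounds shown, and "the series" means these compounds.

Compound 2 `Clc1ccc(-c2cn3ccnc3c(-c3ccc4ncn(C5CCCCC5)c4c3)n2)cc1` gives 4.14% in a functional assay on NCI-H460 cells (Homo sapiens) for inhibition, read by sulforhodamine B assay, with a stated time of 48 h, tested at 10 uM (a lower number here means less inhibition, a higher number more inhibition at the concentration tested (going by the name of the read-out)), and stands alongside compound 1 `c1ccc2c(-c3cn4ccnc4c(-c4ccc5ncn(C6CCCCC6)c5c4)n3)cccc2c1`, which gives 3.61%; the step of a number 0.5 percentage points higher from compound 1 to compound 2 (within the scatter) lies within the scatter. Compound 3 `Fc1ccccc1-c1cn2ccnc2c(-c2ccc3ncn(C4CCCCC4)c3c2)n1` differs from compound 2 by 2-fluorophenyl in place of 4-chlorophenyl on an aromatic carbon. Among the measured compounds shown here, the only measured step, a number 0.5 percentage points higher from compound 1 to compound 2 (within the scatter), also exchanged the group on this aromatic carbon and produced no change beyond the scatter, so no step beyond the scatter is expected in this assay here either. Compound 3 is therefore estimated at 4%, expected to fall between -8% and 16%, an expected step of a number 0.1 percentage points lower from compound 2 to compound 3 (within the scatter).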

Compound 3, a percentage reported as inhibition, at one concentration (the size of the read-out at that concentration, not a potency): 8.1%
Compound 3: the middle estimate sits 4.1 percentage points below what was measured; low and high end bracket the measured number.
By their numbers in this assay, from the lowest: compounds 1, 2 and 3 (each within the scatter of the next).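

With 2-fluorophenyl, a third aromatic group on this carbon again gives no step beyond the scatter in this assay (a number 4 percentage points higher from compound 2 to compound 3 (within the scatter); a number 4.5 percentage points higher from compound 1 to compound 3 (within the scatter)). Naphthalen-1-yl, 4-chlorophenyl and 2-fluorophenyl therefore cannot be told apart here, even though the last carries a different halogen at a different ring position. No evidence is available to account for this similarity. From the compounds shown here alone, it remains open whether a non-aromatic group at this carbon, such as an amine or a carboxylic acid, would give a step beyond the scatter.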